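Capping the Ring Amine of Compound 1

This account rests on a few compounds, and the source may have more. Where it says the series, first, only, none or still open, it means among the compounds named here.

Measured so far:
compound 1 `FC(F)(F)c1ccc(Nc2nc(NC3CCCNC3)nc3c2CCN(c2ncccc2C(F)(F)F)CC3)cc1` gives > 5000 nM in a functional assay on HEK293 cells for antagonist activity at transient receptor potential cation channel subfamily V member 1 (Rattus norvegicus), read by FLIPR and calcium flux; on this read-out higher numbers stand for weaker inhibition and lower numbers for stronger inhibition
compound 2 `NC1CCN(c2nc3c(c(Nc4ccc(C(F)(F)F)cc4)n2)CCN(c2ncccc2C(F)(F)F)CC3)C1` gives > 5000 nM in this assay

In this assay compound 1 reaches only a limit, > 5000 nM, not a number. Compound 2 also stops at a limit, > 5000 nM. The step that the two limits leave unreadable from compound 1 to compound 2 cannot be read, since both values sit at the limit of > 5000 nM in this assay, at which 2 of the 2 values shown sit.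

Compound 3 `CC(C)(C)OC(=O)N1CCCC(Nc2nc3c(c(Nc4ccc(C(F)(F)F)cc4)n2)CCN(c2ncccc2C(F)(F)F)CC3)C1` differs from compound 1 by tert-butoxycarbonyl in place of hydrogen on an amine nitrogen in a ring. Among the measured compounds shown here, no measured step touches this change, and compound 1 itself offers only a limit, so the expected step that the limit leaves unreadable from compound 1 to compound 3 rests on that limit alone. Compound 3 is expected to give about 8000 nM, between 3000 nM and 30000 nM, most likely again as a limit.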

Compound 3, half-maximal inhibitory concentration: 239 nM
Estimate against measurement, compound 3: 33-fold (1.52 log units) above; the whole stated range lies above it.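

Placing tert-butoxycarbonyl on the amine nitrogen in the ring gives an at least 20-fold lower number from compound 1 to compound 3 (1.32 log units; beyond the scatter) in this assay. The earlier compounds shown here changed only how the amine-bearing ring is attached to the shared core, and neither yielded a number. This cap makes compound 3 the only compound shown that gives a number rather than a limit: the limit of > 5000 nM in this assay, at which 2 of the 3 values shown sit.

As far as these compounds go, whether this step is specific to tert-butoxycarbonyl remains open, as a smaller acetyl or methyl group on the same nitrogen would be needed to tell. From the compounds shown here alone, the effect of the same cap on the amine of compound 2 also remains open.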